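The source may report more compounds than this note shows. Statements on the series, on what has been measured and on what is new or still open speak of the compounds shown alone.

Measured so far in a functional assay on the whole organism (integument) for inhibition, with Chilo suppressalis as the target, read by scintillation counting, with a stated time of 72 h; a lower number here means a stronger inhibitor, a higher number a weaker inhibitor:
- compound 1, `O=C(Nc1nnc(-c2ccc(Cl)cc2)s1)c1ccccc1`: its result is a limit of the assay, > 5010 nM, not a number.
- compound 2, `COc1ccccc1C(=O)Nc1nnc(-c2ccc(Cl)cc2)s1`: 53.7 nM.
- compound 3, `COc1cccc(OC)c1C(=O)Nc1nnc(-c2ccccc2)s1`: 2950 nM.

Going by the values given here, compound 3 stands at the highest of the two numbers, which makes it the weaker inhibitor of the two; the only other number is that of compound 2, which is far lower. Compound 4, `COc1cccc(OC)c1C(=O)Nc1nnc(-c2ccc(C(C)(C)C)cc2)s1`, differs from compound 3 in one place: tert-butyl in place of hydrogen on an aromatic carbon, placed on a six-membered aromatic ring of carbon only, para to a large group. Among the compounds with values here, only one measured step is available: an at least 93-fold lower number from compound 1 to compound 2 (1.96 log units; beyond the scatter), a large change, though it concerns a methoxy on a different ring and rests on a limit, (the limit of > 5010 nM in this assay, at which 1 of the 3 values shown sits). Compound 2, which also carries a chloro group on the ring that compound 4 substitutes, sits at a much lower number than compound 3. Within the data shown here, a group on that ring may therefore matter, but no measured step isolates it. A moderate lowering of the number is expected in this assay, a 3.7-fold lower number from compound 3 to compound 4 (0.57 log units; beyond the scatter). Compound 4 is estimated at 800 nM, in the range 150 nM to 4000 nM.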

Compound 4, half-maximal inhibitory concentration: 912 nM
Estimate against measurement, compound 4: 1.1-fold (0.06 log units) below; low and high end bracket the measured number.
By their numbers in this assay, from the lowest: compound 2; then compound 4; then compound 3. At a limit, above all of these: compound 1.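

In this assay adding tert-butyl in place of hydrogen gives a 3.2-fold lower number from compound 3 to compound 4 (0.51 log units; beyond the scatter) and so shows that this aromatic carbon, para to a large group, accepts a group of this size with a modest gain in inhibition. It is the first step shown with a change on this ring, and it joins two true numbers, so its size can be read directly, unlike that of the earlier step from compound 1. Nothing shown here gives a reason for the size of this change.

On these data alone, whether a methyl group or an amine at this same place would lower the number further remains open. Going by these compounds alone, the chloro group of compound 2 cannot be weighed against the tert-butyl of compound 4, since no single step links these two compounds.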